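From a Fluorophenyl to a Dichlorophenyl Group

This account rests on a few compounds, and the source may have more. Where it says the series, first, only, none or still open, it means among the compounds named here.

In an assay on cells for inhibition of histone deacetylase 8 (Homo sapiens), read by fluorescence, with a stated time of 30 min (a lower number here means a stronger inhibitor, a higher number a weaker inhibitor), compound 3 `O=C1NC(=O)/C(=C\c2ccc(OCC(=O)N3N=C(c4ccccc4)CC3c3ccc(F)cc3)cc2)S1` gives 26000 nM, numerically the highest of the three numbers, with both other compounds within the scatter of it: compound 1 `O=C1NC(=O)/C(=C\c2ccc(OCC(=O)N3N=C(c4ccccc4)CC3c3ccccc3)cc2)S1` gives 20000 nM and compound 2 `O=C1NC(=O)/C(=C\c2ccc(OCC(=O)N3N=C(c4ccccc4)CC3c3ccc(C(F)(F)F)cc3)cc2)S1` gives 16000 nM. Within the data shown here, the steps that bear on the present change were small: a 1.3-fold higher number from compound 1 to compound 3 (0.11 log units; within the scatter) and a 1.6-fold higher number from compound 2 to compound 3 (0.21 log units; within the scatter). Compound 4 `O=C1NC(=O)/C(=C\c2ccc(OCC(=O)N3N=C(c4ccccc4)CC3c3ccc(Cl)c(Cl)c3)cc2)S1` carries the change (3,4-dichlorophenyl in place of 4-fluorophenyl on a saturated ring carbon). Since neither earlier substitution on this ring moved the number beyond the scatter, the estimated step of a 1.3-fold lower number from compound 3 to compound 4 (0.11 log units; within the scatter) is expected to carry no direction beyond the scatter either. Compound 4 is therefore estimated at 20000 nM, within a range from 9000 nM to 45000 nM.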

Compound 4, half-maximal inhibitory concentration: 10000 nM
The estimate for compound 4 lay 2.0-fold (0.30 log units) above the measured number; the measured number falls inside the stated range.
By their numbers in this assay, from the lowest: compounds 4, 2, 1 and 3 (each within the scatter of the next, the first and the last beyond it).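

In this assay, among these compounds, 3,4-dichlorophenyl gives the first step at this saturated ring carbon that lies beyond the scatter, a 2.6-fold lower number from compound 3 to compound 4 (0.41 log units; beyond the scatter). The same group stays within the scatter of the other two aryl groups, with a 1.6-fold lower number from compound 2 to compound 4 (0.20 log units; within the scatter) and a 2.0-fold lower number from compound 1 to compound 4 (0.30 log units; within the scatter), so only the comparison with 4-fluorophenyl sets it apart. Nothing available here accounts for this step. The compounds shown leave open whether a phenyl group bearing a single chloro substituent, an amine or a carboxylic acid would differ from compound 1 beyond the scatter.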